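Adenosine-derived amine series against the C38 methyltransferase

The compounds below may be only part of what the source reports. "The series", "measured", "known", "first", "only" and "open" are said of these compounds alone.

Measured compounds:
compound 1 `Nc1ncnc2c1ncn2[C@@H]1O[C@H](CSCCCC(=O)O)[C@@H](O)[C@H]1O`: no result reported in an assay for inhibition of tRNA (cytosine(38)-C(5))-methyltransferase (Homo sapiens), with a stated time of 5 min, tested at 100 uM; a higher number here means more inhibition at the concentration tested (going by the name of the read-out), a lower number less inhibition
compound 2 `Nc1ncnc2c1ncn2[C@@H]1O[C@H](CNC(=O)CC[C@H](N)C(=O)O)[C@@H](O)[C@H]1O`: no result reported in this assay
compound 3 `Nc1ncnc2c1ncn2[C@@H]1O[C@H](CN(CC[C@H](N)C(=O)O)CC2CCC2)[C@@H](O)[C@H]1O`: 32% in this assay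

For the measured compounds named here, compound 3 is the only member of the series with a number; compounds 1 and 2, which carry a thioether-linked acid and an amide-linked amino acid on the shared core, gave no result. Going by the values given here, with a single value nothing can be said of how the series as a whole behaves, and no step between measured compounds exists to set a scale for the change that follows.

Compound 4 `CCC#CCN(CC[C@H](N)C(=O)O)C[C@H]1O[C@@H](n2cnc3c(N)ncnc32)[C@H](O)[C@@H]1O` keeps the amine and the amino-acid chain of compound 3 and changes only the other substituent on the nitrogen: but-1-yn-1-yl in place of cyclobutyl on a saturated chain carbon bound to an amine nitrogen. Both groups have the same number of heavy atoms, with no donor or acceptor gained or lost.

Compound 4 is expected to land close to compound 3, with a step of a number 2 percentage points lower from compound 3 to compound 4 (within the scatter) that does not clearly exceed the usual scatter. The estimate for compound 4 is 30%, with a range from 10% to 50%.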

Compound 4, a percentage reported as inhibition, at one concentration (the size of the read-out at that concentration, not a potency): 62.8%
Compound 4: the middle estimate sits 32.8 percentage points below what was measured, outside the stated range (above it).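

In this assay, the substituent on the amine nitrogen proves to be a sensitive point in the series: but-1-yn-1-yl in place of cyclobutyl, on a saturated chain carbon bound to an amine nitrogen, brings a number 30.8 percentage points higher from compound 3 to compound 4 (beyond the scatter). Heavy-atom, donor and acceptor counts stay the same across this change, while the four-membered ring leaves and a triple bond enters, and this single pair cannot separate those two differences. Nothing measured here bears on why the step is this large.

As far as these compounds go, it remains open whether the step goes with the triple bond or simply with the open chain, a question that a plain pentyl chain in place of pent-2-yn-1-yl would address. Also open, from the compounds shown here alone, is how a longer alkyne chain on the same nitrogen would read out.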